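The source may hold more compounds than are shown below. What is called first, only, known or untested is meant among the compounds shown, and "the series" means these compounds.

Compound 3 `Cc1ccc2[nH]c(-n3[nH]c(C)c(Cc4ccc(C(F)(F)F)cc4)c3=O)nc2c1` is the point of departure. In an assay on isolated protein for inhibition of alpha-ketoglutarate-dependent dioxygenase alkB homolog 3 (Homo sapiens), read by polymerase chain reaction, with a stated time of 1 h (on this read-out higher numbers stand for weaker inhibition and lower numbers for stronger inhibition), compound 3 gives 570 nM. Compound 1 `Cc1ccc2[nH]c(-n3[nH]c(C)c(Cc4ccccc4)c3=O)nc2c1` carries hydrogen where compound 3 carries trifluoromethyl; in this assay compound 1 gives 670 nM, and compound 2 `Cc1[nH]n(-c2nc3ccccc3[nH]2)c(=O)c1Cc1ccc(-c2ccccc2)cc1` gives 720 nM. The three numbers sit within the usual scatter of one another, so compound 3 stands level with the other two rather than apart from them. Among the compounds with values here, the one step that can be followed, a 1.2-fold lower number from compound 1 to compound 3 (0.07 log units; within the scatter), confirms this: trifluoromethyl in place of hydrogen on an aromatic carbon left the number essentially where it was.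

Compound 4 `Cc1ccc2[nH]c(-n3[nH]c(C)c(Cc4ccc(-c5ccccc5)cc4)c3=O)nc2c1` differs from compound 3 in one place: phenyl in place of trifluoromethyl on an aromatic carbon. Within the data shown here, no measured step covers this exchange directly. What bears on it is compound 2, which already carries the phenyl in the same manner and lacks only the methyl on the shared core; compound 2 with its 720 nM lies within the scatter of both compound 1 and compound 3. Together with a 1.2-fold lower number from compound 1 to compound 3 (0.07 log units; within the scatter), this suggests that the groups tried so far at this place have not shifted this assay beyond the scatter. The step of a 1.1-fold higher number from compound 3 to compound 4 (0.06 log units; within the scatter) is therefore expected to stay within the scatter. The estimate for compound 4 is 650 nM, with a range from 300 nM to 1400 nM.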

Compound 4, half-maximal inhibitory concentration: 5300 nM
For compound 4 the middle estimate is 8.2-fold (0.91 log units) below the measured one; measured number above the stated range.
By their numbers in this assay, from the lowest: compounds 3, 1 and 2 (each within the scatter of the next); then compound 4.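

In this assay, the aromatic carbon para to a large group proves less forgiving than compound 1 and compound 3 indicated: trifluoromethyl stood within the scatter of hydrogen there, yet phenyl gives a 7.9-fold higher number from compound 1 to compound 4 (0.90 log units; beyond the scatter) and a 9.3-fold higher number from compound 3 to compound 4 (0.97 log units; beyond the scatter). The phenyl does not act alone, as the methyl on the shared core also separates two phenyl-bearing compounds, with a 7.4-fold higher number from compound 2 to compound 4 (0.87 log units; beyond the scatter); compound 2 stays level with compound 1 and compound 3, while compound 4 does not, so the phenyl is accommodated in one core and not in the other. No measurement at hand bears on why these steps arise.

The compounds shown leave open whether the methyl on the core changes the number when the phenyl is absent, as no pair with hydrogen or trifluoromethyl at the para carbon differs in that methyl alone. Also open, going by these compounds, is how groups of other kinds would read on the methylated core at this place, such as a methoxy group, an amine or a carboxylic acid, and whether any of them would remain level with compound 3.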